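Isopropyl in place of methoxy: outlook for compound 4

The source may report more compounds than this note shows. Statements on the series, on what has been measured and on what is new or still open speak of the compounds shown alone.

The series shares one core and varies a single group on the outer aromatic carbon. In a functional assay on PC-3 cells (Homo sapiens) for antiproliferative activity, read by MTT assay, with a stated time of 48 h (on this read-out higher numbers stand for weaker inhibition and lower numbers for stronger inhibition), compound 1 `Cc1cnc(Nc2ccc(Cl)cc2)nc1Nc1nc2ccccc2s1` gives > 50000 nM, a limit of the assay rather than a number. Compound 2 `Cc1cnc(Nc2ccc(F)cc2)nc1Nc1nc2ccccc2s1` likewise gives > 50000 nM, again a limit. Compound 3 `COc1ccc(Nc2ncc(C)c(Nc3nc4ccccc4s3)n2)cc1` gives > 50000 nM, also a limit. All three therefore sit together at the limit of > 50000 nM in this assay, at which 3 of the 3 values shown sit, and the steps a step that the two limits leave unreadable from compound 1 to compound 2, a step that the two limits leave unreadable from compound 1 to compound 3 and a step that the two limits leave unreadable from compound 2 to compound 3 cannot be read in size or direction.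

Compound 4 `Cc1cnc(Nc2ccc(C(C)C)cc2)nc1Nc1nc2ccccc2s1` differs from compound 3 by isopropyl in place of methoxy on an aromatic carbon. For the measured compounds named here, no measured step involves isopropyl, and the three steps that touch this position are all unreadable, so nothing here shows that any change at this carbon moves the read-out off the limit. The expectation for compound 4 in this assay is therefore that it stays near the limit, with a step of a number no higher from compound 3 to compound 4 (the limit leaves the size open) estimated as no more than the scatter. Compound 4 is estimated at 50000 nM, ranging from 15000 nM to 100000 nM.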

Compound 4, half-maximal inhibitory concentration: > 50000 nM
Compound 4: a limit, no number; the forecaster's own chance of this, stated with the estimate: 70%; the middle value sits exactly at the limit.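

In this assay compound 4 gives > 50000 nM as a limit and not a number. Its steps from compound 1, compound 2 and compound 3 therefore cannot be read, as all four compounds sit together: the limit of > 50000 nM in this assay, at which 4 of the 4 values shown sit. Going by these compounds, whether any group at this aromatic carbon moves the read-out off the limit stays open.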